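Oral exposure notes: changing the aromatic nitrogen substituent

The compounds below may be only part of what the source reports. "The series", "measured", "known", "first", "only" and "open" are said of these compounds alone.

- compound 1 `Cc1ccc(C(=O)Nc2cccc(C(F)(F)F)c2)cc1-c1ccc2c(-c3cnn(C)c3)n[nH]c2c1` at 3480 ng.h/mL
- compound 2 `Cc1ccc(C(=O)Nc2cccc(C(F)(F)F)c2)cc1-c1ccc2c(-c3cnn(C4CC4)c3)n[nH]c2c1` at 7640 ng.h/mL
- compound 3 `Cc1ccc(C(=O)Nc2cccc(C(F)(F)F)c2)cc1-c1ccc2c(-c3cnn(CC(C)O)c3)n[nH]c2c1` not yet measured

In an ADME assay on the whole organism (Mus musculus, strain ICR(CD-1)) for pharmacokinetics, read by mass spectrometry, at a dose of 10 mg/kg by the oral route (on this read-out higher numbers stand for higher exposure at the dose given and lower numbers for lower exposure), compound 2 stands highest of the two measured numbers at 7640 ng.h/mL so far. Compound 3 differs from compound 2 by the change 2-hydroxypropyl in place of cyclopropyl on an aromatic nitrogen with 2-hydroxypropyl in place of cyclopropyl on an aromatic nitrogen. Within the data shown here, the only measured step on that nitrogen, a 2.2-fold higher number from compound 1 to compound 2 (0.34 log units; beyond the scatter) and modest, gives the size to work from. Among the measured compounds shown here, no measured compound carries 2-hydroxypropyl, and the direction remains uncertain. A downward move of similar size is expected, with a 2.0-fold lower number from compound 2 to compound 3 (0.30 log units; within the scatter) as the estimated step for now. For compound 3 the expected value is 3800 ng.h/mL within an estimated range of 1300 ng.h/mL to 10000 ng.h/mL at this stage.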

Compound 3, area under the concentration-time curve: 324 ng.h/mL
Estimate against measurement, compound 3: 12-fold (1.07 log units) above, and the stated range ends above it.
By their numbers in this assay, from the lowest: compound 3; then compound 1; then compound 2.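

On this aromatic nitrogen, the substituent can shift this assay far more than the methyl and cyclopropyl pair indicated: 2-hydroxypropyl in place of cyclopropyl gives a 24-fold lower number from compound 2 to compound 3 (1.37 log units; beyond the scatter), and the extension of methyl to 2-hydroxypropyl gives an 11-fold lower number from compound 1 to compound 3 (1.03 log units; beyond the scatter). Among these three compounds, the 2-hydroxypropyl group gives the lowest exposure. Nothing available explains this loss.

As far as these compounds go, it remains open whether the fall follows the hydroxyl group or the open chain itself. A plain propyl chain on the same nitrogen would separate the two, and a chain ending in an amine would widen the comparison.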